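Pyridyl swap on a shared core: expected exposure of compound 4

A few compounds are considered here, and "the series" means these few. Any claim that something is new, unique, unknown or untested is made for them only; others in the source may bear on it.

Measured so far in an ADME assay on the whole organism (strain Zucker) for pharmacokinetics, with Rattus norvegicus as the target, with stated times of 24 h and 14 days, at a dose of 3 mg/kg by the oral route; a lower number here means less compound in the circulation, a higher number more compound in the circulation at the dose given:
- compound 1, `Cn1c(COc2cccc(C(=O)O)c2)nc2ccc(Oc3ccc4c(c3)OCC4)nc21`, gives 3390 ng.h/mL
- compound 2, `Cn1c(COc2cccc(C(=O)O)c2)nc2cnc(Oc3ccc4c(c3)CCC4)cc21`, gives 2410 ng.h/mL
- compound 3, `Cc1cnc(Oc2ccc3nc(COc4cccc(C(=O)O)c4)n(C)c3c2)c(F)c1`, gives 3610 ng.h/mL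

All three share the same core, an acid-bearing arm and an ether-linked aromatic group, and differ only in that ether-linked group. The number for compound 3 is the highest of the three, yet its gaps to compound 1 and to compound 2 both lie within the usual scatter of this assay, so the three results cannot be told apart with any confidence. No pair of these compounds differs in just one place, so no single structural step can be read off from the measured numbers.

Compound 4, `Cc1cc(Cl)cnc1Oc1ccc2nc(COc3cccc(C(=O)O)c3)n(C)c2c1`, keeps the same core and differs from compound 3 in one place: 5-chloro-3-methylpyridin-2-yl in place of 3-fluoro-5-methylpyridin-2-yl on an oxygen on an aromatic ring. Among the compounds with values here, with no comparable step measured, the expectation rests on how little the three measured compounds differ from one another despite larger changes in the same region. The step from compound 3 to compound 4 is therefore estimated as a 1.1-fold lower number from compound 3 to compound 4 (0.05 log units; within the scatter), with no direction beyond the scatter. Compound 4 is expected to give about 3200 ng.h/mL, within a range from 1300 ng.h/mL to 7500 ng.h/mL.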

Compound 4, area under the concentration-time curve: 1250 ng.h/mL
The estimate for compound 4 lay 2.6-fold (0.41 log units) above the measured number; measured number below the stated range.
By their numbers in this assay, from the lowest: compounds 4, 2, 1 and 3 (each within the scatter of the next, the first and the last beyond it).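

Within the data shown here, this position is less forgiving than the earlier compounds suggested. In this assay, among these compounds, placing 5-chloro-3-methylpyridin-2-yl in place of 3-fluoro-5-methylpyridin-2-yl on an oxygen on an aromatic ring gives a 2.9-fold lower number from compound 3 to compound 4 (0.46 log units; beyond the scatter), the only step here that can be read between compounds differing in one place, and it lies beyond the usual scatter. The two groups match in heavy-atom count, in having one six-membered aromatic ring with 1 hetero atom, and in carrying no net charge, so a clear change in exposure can arise even when these counts stay the same, and nothing measured here accounts for it.

The names of the two groups show that fluorine gives way to chlorine and that the methyl group also changes its numbered position, so this single step cannot say which of the two alterations matters more. Also open, going by these compounds, is how a nitrile or a methoxy group in place of the chlorine would behave, and whether an amide in place of the carboxylic acid on the shared arm would alter the exposure.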